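The compounds below may be only part of what the source reports. "The series", "measured", "known", "first", "only" and "open" are said of these compounds alone.

Measured compounds in an ADME assay on MT2 cells (Homo sapiens) for inhibition, read by MTT assay; a higher number here means that more compound is tolerated, a lower number that less compound is tolerated:
- compound 1 `Cc1cc2cc(C#N)ccc2c(C)c1Nc1nc(Cl)nc(Nc2ccc(C#N)cc2)n1`, giving 7500 nM
- compound 2 `N#Cc1ccc(Nc2nccc(Nc3ccc4cc(C#N)ccc4c3F)n2)cc1`, giving 45000 nM
- compound 3 `N#Cc1ccc(Nc2ncnc(Nc3c(F)cc4cc(C#N)ccc4c3F)n2)cc1`, for which the assay reports only a limit, > 100000 nM

Three compounds share a core built from two nitrile-bearing aromatic pieces joined through a central heteroaromatic ring, and they were tested for how much of each is tolerated by the cells. Compound 3 gave only a limit of this assay rather than a number, so it sits at the limit of > 100000 nM in this assay, at which 1 of the 3 values shown sits, and cannot be ranked against the others. Of the two numbers that remain, compound 2 gives the higher one and compound 1 the lower, and the gap between them lies beyond the usual scatter of this kind of measurement.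

Compound 4 `N#Cc1ccc(Nc2nccc(Nc3ccc4cc(C#N)ccc4c3)n2)cc1` has not yet been measured. It differs from compound 2 in a single place: hydrogen in place of fluoro on an aromatic carbon. Within the data shown here, no pair of measured compounds shows this particular change, so there is no measured step to lean on. The author expects the step of a 1.1-fold lower number from compound 2 to compound 4 (0.05 log units; within the scatter) to stay within the scatter, in neither direction, and estimates for compound 4 a value of 40000 nM, within a range from 14000 nM to 100000 nM.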

Compound 4, half-maximal cytotoxic concentration: > 100000 nM
Compound 4: no number, only a limit; the forecaster's own chance of this, stated with the estimate: 15%; middle value at least 2.5-fold (0.39 log units) from the limit.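

In this assay, compound 4 gives only a limit of the assay, > 100000 nM. Hydrogen in place of fluoro on this aromatic carbon, ortho to a fused ring, gives an at least 2.2-fold higher number from compound 2 to compound 4 (0.34 log units; beyond the scatter), the first step in the set between two measured compounds that differ in one place, and it shows that the fluoro at this position is not a neutral feature in this assay, since the cells tolerate more of the compound without it. The step can be read only as a lower bound, because compound 4 stands at a limit and the full size of the change stays hidden: the limit of > 100000 nM in this assay, at which 2 of the 4 values shown sit.

The compounds shown leave open whether another group on this aromatic carbon, such as a methoxy group or an amine, would give a number that can be read within the range of the assay, or would fall nearer to the fluoro compound. They also leave open whether the same exchange of fluoro for hydrogen would move the tolerated concentration in the same direction on the core of compound 1 or of compound 3.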